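A few compounds are considered here, and "the series" means these few. Any claim that something is new, unique, unknown or untested is made for them only; others in the source may bear on it.

The measured compounds:

Compound 1, `N=C(Nc1cccc2ccccc12)N(c1ccccc1)c1cccc2ccccc12`, in an assay on membranes from brain (Cavia porcellus) for binding affinity to Sigma non-opioid intracellular receptor 1 (Homo sapiens), read by radioligand binding (a lower number here means a stronger inhibitor, a higher number a weaker inhibitor), gives 7930 nM.
Compound 2, `CN(C(=N)N(c1ccccc1)c1cccc2ccccc12)c1cccc2ccccc12`, in this assay gives 11000 nM.
Compound 3, `Cc1cccc(NC(=N)Nc2cccc3ccccc23)c1`, in this assay gives 75 nM.

Compound 2 differs from compound 1 by methyl in place of hydrogen on a nitrogen on an aromatic ring. That change made a 1.4-fold higher number from compound 1 to compound 2 (0.14 log units; within the scatter), so the two values cannot be told apart. Compound 3 has a different core from compound 1, and the difference between the two cores is not broken down here; what the values show is that compound 3 gives the lowest number of the three, far below compound 1 and compound 2, beyond the usual scatter in both cases.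

Compound 4, `Cc1cccc(N(C)C(=N)Nc2cccc3ccccc23)c1`, has not yet been measured. It differs from compound 3 by methyl in place of hydrogen on a nitrogen on an aromatic ring. The place of this change is described in the same words as for the change from compound 1 to compound 2, so it is the same change, now made on the core of compound 3. Among the compounds with values here, the one earlier example of it moved the number only within the scatter. The expectation therefore rests on a single pair, on a different core, and the step is estimated as a 2.0-fold higher number from compound 3 to compound 4 (0.30 log units; within the scatter) because the same change earlier gave a 1.4-fold higher number from compound 1 to compound 2 (0.14 log units; within the scatter). Compound 4 is expected to give about 150 nM. The range is estimated as 50 nM to 600 nM for compound 4, wide enough to allow for the change behaving differently on this core.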

Compound 4, half-maximal inhibitory concentration: 1860 nM
The estimate for compound 4 lay 12-fold (1.09 log units) below the measured number, outside the stated range (above it).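

Putting a methyl in place of the hydrogen on the nitrogen of the core of compound 3 gave a 25-fold higher number from compound 3 to compound 4 (1.39 log units; beyond the scatter) in this assay, so on this core the change clearly weakens binding. The same change therefore does not carry over from one core to another in this series with a fixed size, and a step seen on one core is a poor guide to the step on the other, as the two steps differ by more than the scatter of such measurements: the same change on two cores in this assay, a 1.4-fold higher number (0.14 log units; within the scatter) from compound 1 to compound 2 and a 25-fold higher number (1.39 log units; beyond the scatter) from compound 3 to compound 4, 18-fold (1.25 log units) apart, beyond the scatter of two such steps

This does not show which part of the two cores makes the difference, since they differ in more than one place, and two pairs give no rule for what the change would do on a third core.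

Still open, from the compounds shown here alone, is whether a larger group on the same nitrogen, such as ethyl or a longer chain, would follow the step seen with methyl on the core of compound 3. Going by these compounds, it is also open whether that step would keep its size if the methyl on the ring of compound 3 were replaced by a chlorine atom or a methoxy group.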